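Adding a methyl to the chain of compound 3

The source may report more compounds than this note shows. Statements on the series, on what has been measured and on what is new or still open speak of the compounds shown alone.

In a functional assay on NCI-H460 cells (Homo sapiens) for antiproliferative activity, read by MTT assay, with a stated time of 48 h (on this read-out lower numbers stand for stronger inhibition and higher numbers for weaker inhibition), compound 3 (`CCCCC1(O)C(=O)Nc2ccc(Nc3ccc(Cl)cc3)cc21`) gives 24400 nM and compound 1 (`CCCCCC1(O)C(=O)Nc2ccc(Nc3ccc(OC)cc3)cc21`) gives 16200 nM here, so these two numbers lie within the usual scatter of each other. Compound 2 (`CCCCCC1(O)C(=O)Nc2ccc(Nc3ccc(C)cc3)cc21`) reads > 100000 nM and that is a limit of the assay, not a number. Among the measured compounds shown here, the only measured step is an at least 6.1-fold higher number from compound 1 to compound 2 (0.79 log units; beyond the scatter) with methyl in place of methoxy on an aromatic carbon, which is a different change in a different part of the molecule. Compound 4 (`CCCCCC1(O)C(=O)Nc2ccc(Nc3ccc(Cl)cc3)cc21`) differs from compound 3 by methyl in place of hydrogen on a saturated chain carbon, four bonds along the chain from a saturated ring carbon with methyl in place of hydrogen on a saturated chain carbon, four bonds along the chain from a saturated ring carbon. For the measured compounds named here, no measured step makes this change alone. Compound 4 carries the same chain as compound 1, and compound 1 gives 16200 nM, which is within the scatter of the value of compound 3, so no change beyond the scatter is expected. The estimated result is a 1.2-fold lower number from compound 3 to compound 4 (0.09 log units; within the scatter) in this assay for this change. For compound 4 the estimated value is 20000 nM with an expected range from 7000 nM to 60000 nM in this test.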

Compound 4, half-maximal inhibitory concentration: 40800 nM
Compound 4: middle estimate off by 2.0-fold (0.31 log units), on the low side; measured number inside the range.
By their numbers in this assay, from the lowest: compounds 1, 3 and 4 (each within the scatter of the next, the first and the last beyond it). At a limit, above all of these: compound 2.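

In this assay, methyl in place of hydrogen on a saturated chain carbon, four bonds along the chain from a saturated ring carbon, gives a 1.7-fold higher number from compound 3 to compound 4 (0.22 log units; within the scatter), so at this position the longer chain brings no change that can be told from the scatter. With that same chain in all three compounds, the group on the aromatic carbon does show an effect: chloro in place of methoxy gives a 2.5-fold higher number from compound 1 to compound 4 (0.40 log units; beyond the scatter). Compound 2 stands at a limit of the assay, so chloro in place of methyl gives only a bound, an at least 2.4-fold lower number from compound 2 to compound 4 (0.38 log units; beyond the scatter), and not a measured size: the limit of > 100000 nM in this assay, at which 1 of the 4 values shown sits.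

From the compounds shown here alone, whether a still longer chain, such as hexyl, would also leave the number within the scatter remains open. So does the effect of an amine at the end of the chain.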